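A few compounds are considered here, and "the series" means these few. Any claim that something is new, unique, unknown or untested is made for them only; others in the source may bear on it.

Measured so far in a functional assay on Jurkat cells (Homo sapiens) for cytotoxicity, with a stated time of 72 h (a higher number here means that more compound is needed for the effect, a lower number that less compound is needed), each value being a limit and not a number:

Compound 1 `C=C[C@@](C)(/C=C/c1ccc(OS(=O)(=O)C(F)(F)F)cc1)CCC=C(C)C`: > 49000 nM
Compound 2 `C=C[C@](C)(CCCC(C)C)CCc1ccc(O)cc1`: > 49000 nM
Compound 3 `C=C[C@@](C)(/C=C/c1ccc(O)cc1)CCC1OC1(C)C`: > 49000 nM

Compound 3 stands at > 49000 nM, which is a limit of the assay. It therefore gives no number from which to measure a step, and the same holds for the other two compounds. The whole set offers only (the limit of > 49000 nM in this assay, at which 3 of the 3 values shown sit).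

The next compound is compound 4 `C=C[C@@](C)(/C=C/c1ccc(O)cc1)CC/C=C/C(=O)OCC`, which carries one change from compound 3: 2-(ethoxycarbonyl)ethenyl in place of 3,3-dimethyloxiran-2-yl on a saturated chain carbon, three bonds along the chain from two double-bonded chain carbons. The ester-bearing 2-(ethoxycarbonyl)ethenyl thus replaces the 3,3-dimethyloxiran-2-yl, and the rest of the structure stays as it was.

Among the measured compounds shown here, no step between measured compounds exists to show how large such a change might be in this assay. The set contains no measured number, only (the limit of > 49000 nM in this assay, at which 3 of the 3 values shown sit). The expectation is therefore cautious: a modest move toward less compound being needed, or no visible change at all, with a real chance that compound 4 also reaches the limit.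

The expected step is an at least 1.2-fold lower number from compound 3 to compound 4 (0.11 log units; that floor lies within the scatter). For compound 4 the estimated value is 38000 nM, with an expected range of 14000 nM to 60000 nM.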

Compound 4, half-maximal effective concentration: > 49000 nM
Compound 4 ended at the assay's limit; the forecaster's own chance of this, stated with the estimate: 55%; middle value at least 1.2-fold (0.11 log units) from the limit.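

In this assay compound 4 gives > 49000 nM, which is a limit and not a number. Compound 3 also stands at a limit, and no step can be read between compound 3 and compound 4. The compounds shown leave open what number any of them would give and whether any structural change shifts it: the limit of > 49000 nM in this assay, at which 4 of the 4 values shown sit.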